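A few compounds are considered here, and "the series" means these few. Any claim that something is new, unique, unknown or untested is made for them only; others in the source may bear on it.

Measured in a functional assay on CCRF-CEM cells (Homo sapiens) for inhibition, read by sulforhodamine B assay, with a stated time of 48 h, tested at 10 uM; on this read-out higher numbers stand for more inhibition of growth at the one concentration tested and lower numbers for less inhibition of growth:
- Compound 1 `CC(=O)c1ccc(NC(=O)Cn2nc(-c3ccc(Cl)cc3)nc2N)cc1`: 19.9%
- Compound 2 `C/C(=N\O)c1ccc(NC(=O)Cn2nc(-c3ccc(Cl)cc3)nc2N)cc1`: 14.7%
- Compound 3 `COc1ccc(-c2nc3sc(-c4ccccc4)cn3n2)cc1`: 35%

Compound 1 lies within the scatter of compound 2 and clearly lower than compound 3, the only one of the three beyond the scatter from it. Compound 4 `CC(=O)c1ccc(NC(=O)Cn2nc(C(F)(F)F)nc2N)cc1` keeps the core of compound 1 with one change: trifluoromethyl in place of 4-chlorophenyl on an aromatic carbon. For the measured compounds named here, the only measured step, a number 5.2 percentage points lower from compound 1 to compound 2 (within the scatter), sits at a different place, so it says little about this swap. With no measured guide at this place, no step beyond the scatter is expected in this assay, though the swap is large and the uncertainty wide. The estimated move is a number 4.9 percentage points lower from compound 1 to compound 4 (within the scatter). For compound 4 the estimated value is 15%, with an expected range of 3% to 32%.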

Compound 4, percent growth inhibition at one concentration: 6.78%
Compound 4: the middle estimate sits 8.2 percentage points above what was measured, and the stated range covers the measured number.
By their numbers in this assay, from the lowest: compounds 4, 2 and 1 (each within the scatter of the next, the first and the last beyond it); then compound 3.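

Trifluoromethyl in place of 4-chlorophenyl gives a number 13.1 percentage points lower from compound 1 to compound 4 (beyond the scatter) in this assay and so marks this aromatic carbon of the five-membered ring as a place where the read-out responds. For the compounds shown here, the only earlier step lay at a different place and stayed within the scatter, so it could not show this. The swap removes the ring and the chlorine together, and no measured evidence explains the drop.

Still open, from the compounds shown here alone, is how an unsubstituted phenyl or a short chain such as ethyl would fare at this position, which would help separate the role of the ring from that of the chlorine.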